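A Methoxy Group Enters Compound 1

The compounds below may be only part of what the source reports. "The series", "measured", "known", "first", "only" and "open" are said of these compounds alone.

Compound 1 `O=C(NOCc1ccccc1Cl)c1cn(-c2ccccc2)nc1-c1ccccc1` stands at the higher end of the two numbers measured in a functional assay on A549 cells (Homo sapiens) for antiproliferative activity, read by MTT assay, with a stated time of 48 h, in the presence of a further agent that is not named here (on this read-out lower numbers stand for stronger inhibition of growth and higher numbers for weaker inhibition of growth), where compound 1 gives 10300 nM. Compound 2 `O=C(NOCc1ccc(Cl)cc1Cl)c1cn(-c2ccccc2)nc1-c1ccccc1` gives 7350 nM in this assay, and the step of a 1.4-fold lower number from compound 1 to compound 2 (0.15 log units; within the scatter) came with chloro in place of hydrogen on an aromatic carbon. Compound 3 `COc1ccc(-c2nn(-c3ccccc3)cc2C(=O)NOCc2ccccc2Cl)cc1` differs from compound 1 by methoxy in place of hydrogen on an aromatic carbon. Within the data shown here, no measured step adds a methoxy group, and the only step available stayed within the scatter, so no change beyond the scatter is expected here: the step of a 1.1-fold lower number from compound 1 to compound 3 (0.04 log units; within the scatter) is an estimate. Compound 3 is expected to give 9500 nM in this assay, between 3500 nM and 26000 nM.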

Compound 3, concentration for 50% growth inhibition: 2450 nM
The estimate for compound 3 lay 3.9-fold (0.59 log units) above the measured number; the measured number lies below the stated range.
By their numbers in this assay, from the lowest: compound 3; then compounds 2 and 1 (each within the scatter of the next).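

In this assay, among these compounds, the change from phenyl to 4-methoxyphenyl gives a 4.2-fold lower number from compound 1 to compound 3 (0.62 log units; beyond the scatter) and is the first step here beyond the scatter. It shows that the number can respond clearly to a group placed on this aromatic carbon, para to a large group. No measurement on hand accounts for this step.

A single group at this place cannot show whether the oxygen or the whole methoxy group matters. A hydroxyl, an amine or a longer ether chain here could follow the same direction or depart from it.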